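This account rests on a few compounds, and the source may have more. Where it says the series, first, only, none or still open, it means among the compounds named here.

Working notes on the series. Compound 1 `CN1CCN(CC(=O)Nc2nc3ccccc3[nH]2)CC1` gives 45% in a functional assay, read by spectrophotometry, with a stated time of 30 min, tested at 100 ug/mL (a lower number here means a weaker effect, a higher number a stronger effect of the compound at the concentration tested), and compound 2 `CCN1CCN(CC(=O)Nc2nc3ccccc3[nH]2)CC1` gives 45.7% in this assay. The only step so far, a number 0.7 percentage points higher from compound 1 to compound 2 (within the scatter), leaves the two numbers within the scatter of each other, so compound 2 is not set apart from compound 1 on the numbers shown.

Compound 3 `O=C(CN1CCN(c2ncccn2)CC1)Nc1nc2ccccc2[nH]1` carries a different change: pyrimidin-2-yl in place of ethyl on an amine nitrogen in a ring. Within the data shown here, the one measured step concerns a methyl on a saturated chain carbon and offers no guide to exchanging ethyl for pyrimidin-2-yl on the ring nitrogen. With no step of this kind in hand, the expectation defaults to no shift beyond the scatter, while the range is held wide for the untried group.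

For compound 3 the estimated value in this assay is 46%, expected within 28% to 66%, a step of a number 0.3 percentage points higher from compound 2 to compound 3 (within the scatter) expected from compound 2.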

Compound 3, a percentage reported as activity, at one concentration (the size of the read-out at that concentration, not a potency): 46.5%
Compound 3: the middle estimate sits 0.5 percentage points below what was measured, within the range that was stated.
By their numbers in this assay, from the lowest: compounds 1, 2 and 3 (each within the scatter of the next).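

On the amine nitrogen in the ring, pyrimidin-2-yl in place of ethyl brings a number 0.8 percentage points higher from compound 2 to compound 3 (within the scatter) in this assay, and pyrimidin-2-yl in place of methyl brings a number 1.5 percentage points higher from compound 1 to compound 3 (within the scatter). The earlier compounds showed only small alkyl groups on this nitrogen; here a group of 6 heavy atoms with one six-membered aromatic ring, entering for one of 2 heavy atoms with no ring, does not set compound 3 apart from compound 1 or compound 2 on the numbers shown. Nothing at hand offers an explanation for these closely matching numbers.

As far as these compounds go, it remains open whether a phenyl ring, a carboxylic acid or a longer chain on this nitrogen would give a step beyond the scatter. Also open, from the compounds shown here alone, is how any change on the shared core would read in this assay.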